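Cyclopentyl in place of cyclopropyl: notes on compound 4

The compounds below may be only part of what the source reports. "The series", "measured", "known", "first", "only" and "open" are said of these compounds alone.

compound 1 `Cc1cc(CN(CC2CC2)C(CC(=O)O)c2ccc(Cl)cc2)ccc1OCCN1C(=O)CCC1=O` gives 5.2 nm/s
compound 2 `Cc1cc(CN(CC2CC2)[C@@H](CC(=O)O)c2ccc(Cl)cc2)ccc1OCCN1C(=O)CCC1=O` gives 7.3 nm/s
compound 3 `CCCCN(Cc1ccc(OCCN2C(=O)CCC2=O)c(C)c1)C(CC(=O)O)c1ccc(Cl)cc1` gives 13.5 nm/s

All three numbers come from an ADME assay on Caco-2 cells (Homo sapiens) for permeability, read by LC-MS, with a stated time of 2 h (on this read-out lower numbers stand for lower permeability and higher numbers for higher permeability), and make up the whole of the evidence so far. Compound 2 lies within the scatter of both compound 1 and compound 3, although those two stand apart beyond the scatter. One measured pair differs only in its stereo drawing, with the fact that one of compounds 1 and 2 is drawn with a defined configuration and the other without, at the place where they differ as the single difference, and it shows a 1.4-fold higher number from compound 1 to compound 2 (0.15 log units; within the scatter) as its step. That pair offers no guide to the next change.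

Compound 4 `Cc1cc(CN(CC2CCCC2)[C@@H](CC(=O)O)c2ccc(Cl)cc2)ccc1OCCN1C(=O)CCC1=O` departs from compound 2 by cyclopentyl in place of cyclopropyl on a saturated chain carbon bound to an amine nitrogen as its one difference: cyclopentyl in place of cyclopropyl on a saturated chain carbon bound to an amine nitrogen. Among the compounds with values here, the only measured change at that place is propyl in place of cyclopropyl, which gave a 2.6-fold higher number from compound 1 to compound 3 (0.41 log units; beyond the scatter) as a modest upward step. That precedent opens the ring, whereas here the ring stays and grows, so it transfers only loosely. A modest upward move is therefore expected, possibly still within the scatter, and the estimated step is a 1.5-fold higher number from compound 2 to compound 4 (0.18 log units; within the scatter) on that reading. For compound 4 the expected value is 11 nm/s with 5 nm/s to 24 nm/s as its estimated range.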

Compound 4, apparent permeability: 18.1 nm/s
Beside the measured number, compound 4's estimate is 1.6-fold (0.22 log units) below it; the measured number falls inside the stated range.
By their numbers in this assay, from the lowest: compounds 1, 2, 3 and 4 (each within the scatter of the next, the first and the last beyond it).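

At the place on a saturated chain carbon bound to an amine nitrogen, keeping the ring and enlarging it from cyclopropyl to cyclopentyl gives a clear upward step in this assay, namely a 2.5-fold higher number from compound 2 to compound 4 (0.39 log units; beyond the scatter). The earlier compounds shown here showed such a step at this place only with the ring opened, as a 2.6-fold higher number from compound 1 to compound 3 (0.41 log units; beyond the scatter), so an upward step beyond the scatter does not depend on losing the ring, although the two steps start from different compounds and cannot be set against each other as a like-for-like comparison. The one available note on the series, which concerns how compounds 1 and 2 are drawn, does not bear on this change, and nothing given explains the step.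

The compounds shown leave open how the number follows ring size, since cyclobutyl and cyclohexyl would be needed to tell a steady trend from a change peculiar to cyclopentyl. They also leave open whether the upward step survives a ring carrying a hydroxyl group or an amine at this place, as only rings of carbon alone stand here so far.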